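From methoxy to fluoro on an aromatic ring

The source may report more compounds than this note shows. Statements on the series, on what has been measured and on what is new or still open speak of the compounds shown alone.

Measured in a functional assay on A549 cells (Homo sapiens) for antiproliferative activity, read by MTT assay, with a stated time of 72 h; on this read-out lower numbers stand for stronger inhibition and higher numbers for weaker inhibition:
- compound 1 `Cc1ccc(SC(=S)N2CCN(C(=O)OC(C)(C)C)CC2)cc1`: 2110 nM
- compound 2 `CC(C)(C)OC(=O)N1CCN(C(=S)Sc2ccc(C(C)(C)C)cc2)CC1`: 769 nM
- compound 3 `COc1ccc(SC(=S)N2CCN(C(=O)OC(C)(C)C)CC2)cc1`: 712 nM

Compound 3 sits at the low end of these values, level with compound 2, as the series shows a 1.1-fold lower number from compound 2 to compound 3 (0.03 log units; within the scatter). Against the remaining compound the series shows a 3.0-fold lower number from compound 1 to compound 3 (0.47 log units; beyond the scatter).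

The next compound, compound 4 `CC(C)(C)OC(=O)N1CCN(C(=S)Sc2ccc(F)cc2)CC1`, differs by one change: fluoro in place of methoxy on an aromatic carbon. This puts fluoro in place of methoxy on an aromatic carbon, para to a large group.

Swaps at this place have so far been modest at most, with a 2.7-fold lower number from compound 1 to compound 2 (0.44 log units; beyond the scatter) as the other clear example. Going by the values given here, no fluoro compound has been measured, so these steps guide only the likely size. With compound 3 at 712 nM, a new group seems more likely to raise the number than to lower it.

In this assay, a small upward move is expected, a 1.7-fold higher number from compound 3 to compound 4 (0.23 log units; within the scatter). Compound 4 is estimated at 1200 nM, with an expected range from 500 nM to 2800 nM.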

Compound 4, half-maximal inhibitory concentration: 1560 nM
Compound 4: the middle estimate sits 1.3-fold (0.11 log units) below what was measured; low and high end bracket the measured number.
By their numbers in this assay, from the lowest: compounds 3 and 2 (each within the scatter of the next); then compounds 4 and 1 (each within the scatter of the next).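

In this assay, going by these compounds alone, fluoro is the first group at this place to sit clearly above the methoxy level, with a 2.2-fold higher number from compound 3 to compound 4 (0.34 log units; beyond the scatter) as the change, and the tert-butyl compound gives a similar gap, with a 2.0-fold higher number from compound 2 to compound 4 (0.31 log units; beyond the scatter) as the step. Against the methyl compound, a 1.4-fold lower number from compound 1 to compound 4 (0.13 log units; within the scatter) is a step too small to read, so the four compounds fall into two levels: methoxy and tert-butyl at the low numbers, fluoro and methyl at the higher ones, with none of the four going against this split. Nothing measured here bears on why the groups sort this way.

Still open, as far as these compounds go, is how an amine, a hydroxyl group or a carboxylic acid would behave at this place. A longer chain or a trifluoromethyl group could also show whether these two levels hold beyond the four groups seen so far.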